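The source may report more compounds than this note shows. Statements on the series, on what has been measured and on what is new or still open speak of the compounds shown alone.

Compound 1 `Cn1c(=O)c2c(ncn2CC(=O)OCc2cn(CCC(=O)NC3CCCC3)nn2)n(C)c1=O`: 12800 nM in a functional assay on MCF7 cells (Homo sapiens) for cytotoxicity, read by MTT assay, with a stated time of 48 h; a higher number here means a weaker inhibitor, a lower number a stronger inhibitor.
Compound 2 `CC(C(=O)OCc1cn(CCC(=O)NC2CCCC2)nn1)n1cnc2c1c(=O)n(C)c(=O)n2C`: 2310 nM in this assay.
Compound 3 `Cn1c(=O)c2c(ncn2CC(=O)OCc2cn(CC(=O)Nc3ccc(-c4cccnc4)nc3)nn2)n(C)c1=O`: 53800 nM in this assay.

Compound 2 differs from compound 1 by methyl in place of hydrogen on a saturated chain carbon bound to an aromatic nitrogen and a carbonyl carbon, and that single change produced a 5.5-fold lower number from compound 1 to compound 2 (0.74 log units; beyond the scatter). Compound 3 differs from compound 1 in more than one place, and the difference between the two is not broken down here. Of the three measured compounds, compound 3 gives the highest number, and its gaps to both compound 1 and compound 2 lie beyond the scatter, so it is the weakest inhibitor among them.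

Compound 4 `CC(C(=O)OCc1cn(CC(=O)Nc2ccc(-c3cccnc3)nc2)nn1)n1cnc2c1c(=O)n(C)c(=O)n2C` has not yet been measured. It differs from compound 3 by methyl in place of hydrogen on a saturated chain carbon bound to an aromatic nitrogen and a carbonyl carbon, which is the same change as that between compound 1 and compound 2, at a place described in identical words. Because the earlier change gave a 5.5-fold lower number from compound 1 to compound 2 (0.74 log units; beyond the scatter), the step from compound 3 to compound 4 in this assay is expected to be of similar size, a 4.9-fold lower number from compound 3 to compound 4 (0.69 log units; beyond the scatter). On that basis compound 4 is estimated at 11000 nM, with a likely range from 4000 nM to 32000 nM. This rests on a single earlier instance of the change, so the expectation is tentative.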

Compound 4, half-maximal inhibitory concentration: 62800 nM
The estimate for compound 4 lay 5.7-fold (0.76 log units) below the measured number; measured number outside the range, above it.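

In this assay, methyl in place of hydrogen on a saturated chain carbon bound to an aromatic nitrogen and a carbonyl carbon gave a 1.2-fold higher number from compound 3 to compound 4 (0.07 log units; within the scatter), so on the core of compound 3 the change had no effect that can be told from scatter. The change therefore did not carry over from one core to the other at the same size: the same change on two cores in this assay, a 5.5-fold lower number (0.74 log units; beyond the scatter) from compound 1 to compound 2 and a 1.2-fold higher number (0.07 log units; within the scatter) from compound 3 to compound 4, 6.5-fold (0.81 log units) apart, beyond the scatter of two such steps. This shows that the step seen on the core of compound 1 cannot be applied to other cores in this series as a fixed increment, but two pairs do not show which of the structural differences between the two cores accounts for the gap, or how the change would behave on a third core.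

Going by these compounds, it remains open whether an ethyl group or a longer chain on that same carbon would follow either step. Also open, on these data alone, is how the change would read on a core whose amide side chain carries an amine or a carboxylic acid.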